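The compounds below may be only part of what the source reports. "The series", "measured", "known", "first", "only" and "open" are said of these compounds alone.

Three urea analogues built on one shared core have been tested in a functional assay on A-431 cells (Homo sapiens) for antiproliferative activity, read by sulforhodamine B assay, with a stated time of 72 h; a lower number here means a stronger inhibitor, a higher number a weaker inhibitor. Compound 1 `CS(=O)(=O)CCNC(=O)Nc1cc2c(Nc3ccc(F)c(Cl)c3)ncnc2cc1O[C@H]1CCOC1` gives 1570 nM. Compound 2 `COCCCNC(=O)Nc1cc2c(Nc3ccc(F)c(Cl)c3)ncnc2cc1O[C@H]1CCOC1` gives 4100 nM. Compound 3 `CCN(CC)CCN(C)C(=O)Nc1cc2c(Nc3ccc(F)c(Cl)c3)ncnc2cc1O[C@H]1CCOC1` gives 481 nM, the lowest of the three numbers, which makes compound 3 the strongest inhibitor of the set in this assay. Between the first two, the change read as a 2.6-fold higher number from compound 1 to compound 2 (0.42 log units; beyond the scatter). The two steps into compound 3 were larger and both pointed the same way: a 3.3-fold lower number from compound 1 to compound 3 (0.51 log units; beyond the scatter) and an 8.5-fold lower number from compound 2 to compound 3 (0.93 log units; beyond the scatter).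

Compound 4 `O=C(Nc1cc2c(Nc3ccc(F)c(Cl)c3)ncnc2cc1O[C@H]1CCOC1)N1CCC(CCO)CC1` has not yet been measured. It differs from compound 3 by 4-(2-hydroxyethyl)piperidin-1-yl in place of (2-(diethylamino)ethyl)(methyl)amino on a carbonyl carbon. Going by the values given here, the steps that bear on this change are the two that lead into compound 3, a 3.3-fold lower number from compound 1 to compound 3 (0.51 log units; beyond the scatter) and an 8.5-fold lower number from compound 2 to compound 3 (0.93 log units; beyond the scatter), in which chains lacking the diethylamino group gave higher numbers. Among the compounds with values here, compound 4 also lacks that group, though the piperidine with its hydroxyethyl arm resembles none of the measured side chains, so the expectation is loose. Compound 4 is therefore expected to give a higher number than compound 3 in this assay, a step estimated at a 3.1-fold higher number from compound 3 to compound 4 (0.49 log units; beyond the scatter). The estimate for compound 4 is 1500 nM, with a range from 500 nM to 5000 nM.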

Compound 4, half-maximal inhibitory concentration: 759 nM
The estimate for compound 4 lay 2.0-fold (0.30 log units) above the measured number; the measured number falls inside the stated range.
By their numbers in this assay, from the lowest: compounds 3 and 4 (each within the scatter of the next); then compound 1; then compound 2.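

In this assay the low number of compound 3 does not rest on its diethylamino chain: with 4-(2-hydroxyethyl)piperidin-1-yl on the same carbonyl carbon there is a 1.6-fold higher number from compound 3 to compound 4 (0.20 log units; within the scatter), a step within the scatter, so the two compounds cannot be told apart even though a ring bearing a hydroxyethyl arm has replaced an open chain with a second nitrogen. The piperidine side chain also stands clear of the two chains that keep a hydrogen on the nitrogen attached to the carbonyl, with a 5.4-fold lower number from compound 2 to compound 4 (0.73 log units; beyond the scatter) and a 2.1-fold lower number from compound 1 to compound 4 (0.32 log units; beyond the scatter), so among these four compounds the two lowest numbers belong to compounds 3 and 4, which have no such hydrogen. Nothing available explains why these side chains differ in this way.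

Each step replaces a whole side chain, so the missing hydrogen cannot be separated from everything else that changes, and a methyl group on the nitrogen of the 3-methoxypropyl chain would test that point directly. From the compounds shown here alone, it also remains open whether the hydroxyethyl arm matters at all, which a plain piperidine ring or a morpholine ring on the carbonyl carbon would help to settle.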